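Ethoxy to methyl on the carbonyl of compound 2

The source may hold more compounds than are shown below. What is called first, only, known or untested is meant among the compounds shown, and "the series" means these compounds.

Compound 1 `C=C(C)[C@@H]1CC=C(Cn2cc(COc3ccc(C4NC(=O)NC(C)=C4C(=O)OCC)cc3)nn2)CC1` and compound 2 `C=C(C)[C@@H]1CC=C(Cn2cc(COc3ccccc3C3NC(=O)NC(C)=C3C(=O)OCC)nn2)CC1` share one core. In a functional assay on NCI/ADR-RES cells (Homo sapiens) for inhibition, read by sulforhodamine B assay, with a stated time of 48 h (a higher number here means a weaker inhibitor of growth, a lower number a stronger inhibitor of growth), compound 1 reports only a limit, > 100000 nM. In this assay compound 2 likewise reports only a limit, > 100000 nM. Compound 2 thus stands at the limit of > 100000 nM in this assay, at which 2 of the 2 values shown sit. Compound 3 `C=C(C)[C@@H]1CC=C(Cn2cc(COc3ccccc3C3NC(=O)NC(C)=C3C(C)=O)nn2)CC1` differs from compound 2 by methyl in place of ethoxy on a carbonyl carbon. Within the data shown here, no measured step resolves such a change, and both known values are limits. The expected step from compound 2 to compound 3, a step that the limit leaves unreadable from compound 2 to compound 3, is none beyond the scatter. Compound 3 is estimated at 120000 nM, within 40000 nM to 300000 nM, most likely again reported as a limit.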

Compound 3, concentration for total growth inhibition: > 100000 nM
Compound 3: a limit, no number; the forecaster's own chance of this, stated with the estimate: 75%; the middle value does not contradict the limit.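

Among these compounds, compound 2 and compound 3 are both limits, so no step between them can be read: the limit of > 100000 nM in this assay, at which 3 of the 3 values shown sit.
As far as these compounds go, whether ethoxycarbonyl to acetyl changes growth inhibition in this assay stays open, as does any ranking of compound 2 and compound 3.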